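A few compounds are considered here, and "the series" means these few. Any claim that something is new, unique, unknown or untested is made for them only; others in the source may bear on it.

In a functional assay on the whole organism (Cricetulus griseus) with Cricetinae gen. sp. as the target (a lower number here means that less compound is needed, a higher number that more compound is needed for the effect), compound 2, whose structure is `COc1cccc(-c2n[nH]c(-c3cc(C)ccc3C)n2)c1`, gives 2.5 mg/kg. Compound 1, with structure `COc1cccc(-c2n[nH]c(-c3cc(Cl)ccc3C)n2)c1`, differs from it by a single exchange, (chloro in place of methyl on an aromatic carbon), and in this assay compound 1 gives 0.35 mg/kg; the step is a 7.1-fold lower number from compound 2 to compound 1 (0.85 log units; beyond the scatter). Compound 3, with structure `Cc1ccccc1-c1n[nH]c(-c2ccccc2C)n1`, has a different core from compound 2, and the difference between the two cores is not broken down here. In this assay compound 3 gives 0.7 mg/kg.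

Compound 4, with structure `Cc1ccccc1-c1n[nH]c(-c2ccccc2Cl)n1`, has not yet been measured. It is made from compound 3 by chloro in place of methyl on an aromatic carbon. Within the data shown here, this is the same kind of change as the one from compound 2 to compound 1, but not the same: in compound 1 the chloro sits meta to a large group and para to a methyl group, whereas in compound 4 it sits ortho to a large group. The expectation for this assay is a step of a 2.8-fold lower number from compound 3 to compound 4 (0.45 log units; beyond the scatter), a cautious reading because a 7.1-fold lower number from compound 2 to compound 1 (0.85 log units; beyond the scatter) was seen at a different place on the ring. Compound 4 is therefore estimated at 0.25 mg/kg, expected to lie between 0.08 mg/kg and 0.8 mg/kg.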

Compound 4, dose for half-maximal effect: 15 mg/kg
Compound 4: middle estimate off by 60-fold (1.78 log units), on the low side; the whole stated range lies below it.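

In this assay, the exchange of methyl for chloro on an aromatic carbon gave a 21-fold higher number from compound 3 to compound 4 (1.33 log units; beyond the scatter), so this change does not carry over from one core to another as a fixed gain, and here even its direction differs between the two cases: the same change on two cores in this assay, a 7.1-fold lower number (0.85 log units; beyond the scatter) from compound 2 to compound 1 and a 21-fold higher number (1.33 log units; beyond the scatter) from compound 3 to compound 4, 150-fold (2.18 log units) apart, beyond the scatter of two such steps The two pairs also differ in where the exchange happens: in compound 4 the chloro sits ortho to a large group, and in compound 1 it sits at another place on its ring. Among these compounds, with only two pairs, the influence of that place cannot be separated from the influence of the core, and the numbers do not explain the reversal; they show only that the result of this change on one compound was a poor guide to its result on another.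

From the compounds shown here alone, it remains open how other groups, such as fluoro, an amine or a longer chain, would behave at that place on the core of compound 3. Also open, going by these compounds, is what chloro would do on that core at the place it holds in compound 1.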